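The source may hold more compounds than are shown below. What is called first, only, known or untested is meant among the compounds shown, and "the series" means these compounds.

Compound 1 `O=C(CCc1ccncc1-c1ccc2ccccc2c1)N1CCOCC1` and compound 2 `CN(C)C(=O)/C=C/c1ccncc1-c1ccc2ccccc2c1` share one core and differ only in the chain on the ring. In an assay on a protein complex for inhibition of CDK8/Cyclin C (Homo sapiens), with a stated time of 1 h, tested at 10 uM (on this read-out lower numbers stand for less inhibition and higher numbers for more inhibition at the one concentration tested (going by the name of the read-out)), compound 1 gives 100%, and in this assay compound 2 gives 100%, so compound 2 stands level with compound 1 within the scatter. Compound 3 `COC(=O)CCc1ccncc1-c1ccc2ccccc2c1` carries 2-(methoxycarbonyl)ethyl in place of 2-(dimethylcarbamoyl)ethenyl on an aromatic carbon. Within the data shown here, no measured pair shows this change, so its effect is unknown. A small drop or none beyond the scatter is expected. For compound 3 the estimate in this assay is 90%, with a range from 60% to 100%. That estimate means an expected step of a number 10 percentage points lower from compound 2 to compound 3 (within the scatter).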

Compound 3, a percentage reported as inhibition, at one concentration (the size of the read-out at that concentration, not a potency): 98%
Compound 3: middle estimate off by 8 percentage points, on the low side; the measured number falls inside the stated range.
By their numbers in this assay, from the lowest: compounds 3, 1 and 2 (each within the scatter of the next).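

In this assay, 2-(methoxycarbonyl)ethyl in place of 2-(dimethylcarbamoyl)ethenyl gives a number 2 percentage points lower from compound 2 to compound 3 (within the scatter), and methoxy in place of morpholin-4-yl on a carbonyl carbon gives a number 2 percentage points lower from compound 1 to compound 3 (within the scatter). At this aromatic carbon, then, the chain need not carry a nitrogen for the read-out to stay within the scatter. Nothing available explains this result. As far as these compounds go, whether a carboxylic acid, an amine or a longer chain would fare the same remains open. A read-out at one concentration also leaves open how the potencies of these three compounds compare.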